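The source may hold more compounds than are shown below. What is called first, only, known or untested is meant among the compounds shown, and "the series" means these compounds.

Measured compounds, with the concentration at which they kill half the cells:
Compound 1 `CCS[C@@H]1[C@H](SCC)[C@@H](Cn2cc(-c3ccccc3C(F)(F)F)nn2)O[C@H]1n1ccc(=O)[nH]c1=O`: 30300 nM
Compound 2 `CCS[C@@H]1[C@H](SCC)[C@@H](Cn2cc(-c3ccccc3)nn2)O[C@H]1n1cc(C)c(=O)[nH]c1=O`: 65000 nM
Compound 3 `CCS[C@@H]1[C@H](SCC)[C@@H](Cn2cc(-c3ccccc3C(F)(F)F)nn2)O[C@H]1n1cc(C)c(=O)[nH]c1=O`: 22100 nM

In a functional assay on HepG2 cells (Homo sapiens) for cytotoxicity, read by MTT assay, with a stated time of 72 h (a higher number here means that more compound is needed for the effect, a lower number that less compound is needed), compound 3 has the lowest number of the three, although the gap to compound 1 is within the scatter; the gap to compound 2 is not. Compound 4 `CCS[C@@H]1[C@H](SCC)[C@@H](Cn2cc(-c3cccs3)nn2)O[C@H]1n1cc(C)c(=O)[nH]c1=O` differs from compound 3 in one place: thiophen-2-yl in place of 2-(trifluoromethyl)phenyl on an aromatic carbon. The step that bears on this is a 2.9-fold lower number from compound 2 to compound 3 (0.47 log units; beyond the scatter), which shows what removing the trifluoromethyl alone did; a 1.4-fold lower number from compound 1 to compound 3 (0.14 log units; within the scatter) concerns the core and says little here. Since compound 4 loses that trifluoromethyl and gains a smaller ring, a modest rise back toward compound 2 is expected, a 1.8-fold higher number from compound 3 to compound 4 (0.26 log units; within the scatter). Compound 4 is therefore estimated at 40000 nM, within 15000 nM to 110000 nM.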

Compound 4, half-maximal effective concentration: >= 100000 nM
Compound 4 gave a limit, no number; the forecaster's own chance of this, stated with the estimate: 15%; middle value at least 2.5-fold (0.39 log units) from the limit.
By their numbers in this assay, from the lowest: compounds 3 and 1 (each within the scatter of the next); then compound 2. At a limit, above all of these: compound 4.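

Compound 4 reads only as a limit in this assay, not as a number: the limit of >= 100000 nM in this assay, at which 1 of the 4 values shown sits. Thiophen-2-yl in place of 2-(trifluoromethyl)phenyl gives an at least 4.5-fold higher number from compound 3 to compound 4 (0.65 log units; beyond the scatter), so the number in this assay clearly depends on the ring carried at this aromatic carbon. Thiophen-2-yl in place of phenyl gives an at least 1.5-fold higher number from compound 2 to compound 4 (0.18 log units; that floor lies within the scatter), so that floor does not separate these two rings.

On these data alone, what remains open is whether a trifluoromethyl on a thiophen-2-yl ring would lower the number as it does on phenyl. As far as these compounds go, how an amine or a carboxylic acid on the ring would read is also open.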